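Methoxy in Place of Fluoro on the Sulfonyl Phenyl

The source may report more compounds than this note shows. Statements on the series, on what has been measured and on what is new or still open speak of the compounds shown alone.

Of the compounds shown here, three have been measured in a functional assay (trachea) for antagonist activity, with Cavia porcellus as the target; a higher number here means a more potent compound, by a factor of ten per unit of this negative logarithm, a lower number a less potent compound. Compound 1 `CCCCC(CC)C(=O)Nc1ccc2ccn(Cc3ccc(C(=O)NS(=O)(=O)c4ccc(F)cc4)cc3OC)c2c1` gives 7.7, the lowest of the three. Compound 2 `CCCCOC(=O)Nc1ccc2cnn(Cc3ccc(C(=O)NS(=O)(=O)c4ccccc4)cc3OC)c2c1` gives 9.2, and compound 3 `COC(=O)C(C(=O)c1ccc(Cn2ncc3ccc(NC(=O)OC4CCCC4)cc32)c(OC)c1)S(=O)(=O)c1ccccc1` gives 9.9; both stand beyond the scatter above compound 1, with compound 3 the furthest away. Compound 4 `CCCCC(CC)C(=O)Nc1ccc2ccn(Cc3ccc(C(=O)NS(=O)(=O)c4ccc(OC)cc4)cc3OC)c2c1` has not yet been measured in this assay. It differs from compound 1 in one place: methoxy in place of fluoro on an aromatic carbon. Among the measured compounds shown here, no pair of measured compounds differs by such a change alone, so no measured step guides the expectation. The step is expected to be small, a number 0.10 log units higher from compound 1 to compound 4 (within the scatter), with no direction beyond the scatter. Compound 4 is therefore estimated at about 7.8, within a range from 7.2 to 8.4.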

Compound 4, negative logarithm of the antagonist equilibrium constant: 7.4
Beside the measured number, compound 4's estimate is 0.40 log units above it, and the stated range covers the measured number.
By their numbers in this assay, from the lowest: compounds 4 and 1 (each within the scatter of the next); then compound 2; then compound 3.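

In this assay, among the compounds shown here, the change to 4-methoxyphenyl from 4-fluorophenyl gives a number 0.30 log units lower from compound 1 to compound 4 (within the scatter) as the first measured step at this position, para to a large group. With the rest of compound 1 held fixed, these two groups are not told apart by this read-out, although the methoxy adds a hydrogen-bond acceptor. No measurement shown accounts for this result.

The compounds shown leave open whether an amine or a carboxylic acid on this aromatic carbon would give a step beyond the scatter. They also leave open whether the same change would read alike on the core of compound 2.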